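Pyridine isomer step with a single measured anchor

This account rests on a few compounds, and the source may have more. Where it says the series, first, only, none or still open, it means among the compounds named here.

compound 1 (`N#Cc1ccc(N2CCc3cc(-c4cccnc4)ccc32)cc1C(F)(F)F`) gives "not determined" (no result reported)
compound 2 (`CCN(c1cccc(-c2ccccc2)c1)c1ccc(C#N)c(Cl)c1`) gives "not determined" (no result reported)
compound 3 (`N#Cc1ccc(N2CCCc3c(-c4cccnc4)cccc32)cc1C(F)(F)F`) gives 7970 nM

Within the data shown here, in a functional assay on PC-3 cells (Homo sapiens) for antiproliferative activity, read by CCK-8 assay, with a stated time of 6 days (on this read-out lower numbers stand for stronger inhibition and higher numbers for weaker inhibition), compound 3 gives 7970 nM as the only number in the set. Among the measured compounds shown here, the other two entries carry no result, so compound 3 cannot be ranked against them, and the series offers no measured step to show how large a single change can be.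

Compound 4 (`N#Cc1ccc(N2CCCc3c(-c4ccncc4)cccc32)cc1C(F)(F)F`) has the same atoms as compound 3, joined differently. The difference is pyridin-4-yl in place of pyridin-3-yl on an aromatic carbon and amounts to pyridin-4-yl in place of pyridin-3-yl on an aromatic carbon, with the rest of the structure unchanged.

The data give no direction for this swap. With only compound 3 at 7970 nM as an anchor, no step beyond the usual scatter is expected in this assay in either direction, and the range has to stay wide. The expected change, a 1.1-fold lower number from compound 3 to compound 4 (0.06 log units; within the scatter), is an estimate that lies within the scatter. Compound 4 is estimated at 7000 nM (expected range 3000 nM to 16000 nM).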

Compound 4, half-maximal inhibitory concentration: 28700 nM
Compound 4: middle estimate off by 4.1-fold (0.61 log units), on the low side, and the stated range ends below it.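

In this assay, among these compounds, pyridin-4-yl in place of pyridin-3-yl on this aromatic carbon gives a 3.6-fold higher number from compound 3 to compound 4 (0.56 log units; beyond the scatter), a step beyond the usual scatter and the first measured step. Among the compounds shown here, the two groups match in every count, with the same heavy atoms and the same hydrogen-bond acceptor, so the result shows that this position distinguishes between two pyridine isomers, and that pyridin-3-yl is the one with the lower number of this pair. No measurement bears on why the two isomers differ, so the step stands as an observation on one pair only.

Still open, on these data alone, is whether pyridin-2-yl, an unsubstituted phenyl, or a pyridine carrying an amine or a carboxylic acid at this same aromatic carbon would give a lower number than pyridin-3-yl. Also open, as far as these compounds go, is whether a step of this size between the two isomers would persist if the trifluoromethyl group on the nitrile-bearing ring were exchanged for a methoxy group or a longer chain.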